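A few compounds are considered here, and "the series" means these few. Any claim that something is new, unique, unknown or untested is made for them only; others in the source may bear on it.

Measured compounds in a functional assay on NCI/ADR-RES cells (Homo sapiens) for inhibition, read by sulforhodamine B assay, with a stated time of 48 h; on this read-out higher numbers stand for weaker inhibition of growth and lower numbers for stronger inhibition of growth:
compound 1, `C=C1CC[C@@H]2[C@](C)(COC(C)=O)[C@H](OC(C)=O)CC[C@@]2(C)[C@H]1CC(Nc1ccc(S(=O)(=O)Nc2nccs2)cc1)C1=CCOC1=O`, 12700 nM
compound 2, `C=C1CC[C@@H]2[C@](C)(COC(C)=O)[C@H](OC(C)=O)CC[C@@]2(C)[C@H]1CC(Nc1ccc(S(=O)(=O)Nc2ncccn2)cc1)C1=CCOC1=O`, 5280 nM

Within the data shown here, compound 2 holds the lowest of the two numbers so far; the only neighbour is compound 1, and the step of a 2.4-fold lower number from compound 1 to compound 2 (0.38 log units; beyond the scatter) lies beyond the scatter. Both compounds share the same core and differ only in the ring on the sulfonamide nitrogen.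

Compound 3, `C=C1CC[C@@H]2[C@](C)(COC(C)=O)[C@H](OC(C)=O)CC[C@@]2(C)[C@H]1CC(Nc1ccc(S(=O)(=O)Nc2cc(C)on2)cc1)C1=CCOC1=O`, continues from compound 2 with the change (5-methyl-1,2-oxazol-3-yl in place of pyrimidin-2-yl on a sulfonamide nitrogen). Among the measured compounds shown here, the one measured step, a 2.4-fold lower number from compound 1 to compound 2 (0.38 log units; beyond the scatter), concerns a different ring swap on the same sulfonamide nitrogen, so it bears on the present change only indirectly: it shows that exchanging the aromatic ring at this nitrogen can move the number in this assay by a modest amount, but gives no direction for the 5-methyl-1,2-oxazol-3-yl ring itself. For the measured compounds named here, no measured step isolates this particular exchange. The expectation for compound 3 is therefore a number near that of compound 2, with a step of a 1.3-fold higher number from compound 2 to compound 3 (0.12 log units; within the scatter) that is most likely within or only slightly beyond the scatter, direction uncertain. Compound 3 is estimated at 7000 nM, with a range from 2500 nM to 20000 nM.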

Compound 3, concentration for total growth inhibition: 12000 nM
Compound 3: middle estimate off by 1.7-fold (0.23 log units), on the low side; measured number inside the range.
By their numbers in this assay, from the lowest: compound 2; then compounds 3 and 1 (each within the scatter of the next).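

In this assay, the ring on the sulfonamide nitrogen now shows a change in both directions: 5-methyl-1,2-oxazol-3-yl in place of pyrimidin-2-yl gives a 2.3-fold higher number from compound 2 to compound 3 (0.36 log units; beyond the scatter), so the lower number of compound 2 does not carry over to this ring. Set against 1,3-thiazol-2-yl, the same ring gives a 1.1-fold lower number from compound 1 to compound 3 (0.02 log units; within the scatter), which places the two five-membered rings level with each other and leaves the six-membered pyrimidin-2-yl of compound 2 apart from both, a pattern that rests on these three compounds alone and has none among them against it. Nothing available explains this separation.

The compounds shown do not tell whether ring size or the arrangement of hetero atoms goes with the separation, since only one six-membered ring appears; a pyridin-2-yl or a plain phenyl on the sulfonamide nitrogen would bear on that. From the compounds shown here alone, the contribution of the methyl in 5-methyl-1,2-oxazol-3-yl also remains open, and the unsubstituted 1,2-oxazol-3-yl or a 5-ethyl-1,2-oxazol-3-yl would separate it from that of the ring itself.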